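This account rests on a few compounds, and the source may have more. Where it says the series, first, only, none or still open, it means among the compounds named here.

Two methoxy-bearing compounds sharing the same core have been measured so far. In a functional assay on HaCaT cells (Homo sapiens) for antiproliferative activity, read by sulforhodamine B assay, with a stated time of 3 days (on this read-out lower numbers stand for stronger inhibition and higher numbers for weaker inhibition), compound 1 (`COC(=O)c1cc(CCc2ccccc2OC)ccc1O`) gives 20000 nM and compound 2 (`COC(=O)c1cc(CCc2cccc(OC)c2)ccc1O`) gives 37000 nM. These two values lie within the usual scatter of each other, so compound 2 stands level with compound 1 on the numbers available. Compound 3 (`COC(=O)c1cc(CCc2cc(OC)ccc2N(C)C)ccc1O`) departs from compound 2 by one change: dimethylamino in place of hydrogen on an aromatic carbon, ortho to a large group and para to a methoxy group (dimethylamino in place of hydrogen on an aromatic carbon). For the measured compounds named here, no measured pair shows what such a change does in this assay, so the expectation rests only on compound 2 at 37000 nM. A small move toward a lower number is expected, estimated as a 1.9-fold lower number from compound 2 to compound 3 (0.27 log units; within the scatter). For compound 3 the estimated value is 20000 nM, with an expected range from 6000 nM to 60000 nM.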

Compound 3, half-maximal inhibitory concentration: 650 nM
Compound 3: the middle estimate sits 31-fold (1.49 log units) above what was measured, and the stated range ends above it.
By their numbers in this assay, from the lowest: compound 3; then compounds 1 and 2 (each within the scatter of the next).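

In this assay, dimethylamino in place of hydrogen on an aromatic carbon, ortho to a large group and para to a methoxy group, gives a 57-fold lower number from compound 2 to compound 3 (1.76 log units; beyond the scatter), a large step. For the compounds shown here, compounds 1 and 2 stand within the scatter of each other and carry nothing at this place, so this step is the first sign that the position can respond strongly to a substitution. Nothing given here bears on why the step is so large.

As far as these compounds go, whether the step belongs to dimethylamino in particular stays open: a primary amine, a morpholine ring or an acetamide on the same carbon could give a similar or quite different number. Also open, from the compounds shown here alone, is whether dimethylamino would give a step of this size with the methoxy group replaced by hydrogen or a chlorine atom.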